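The source may hold more compounds than are shown below. What is called first, only, known or untested is meant among the compounds shown, and "the series" means these compounds.

Working notes on the series, an assay on HEK293 cells for displacement of a labelled ligand from corticotropin-releasing factor receptor 1 (Homo sapiens), read by scintillation counting, with a stated time of 2 h; a higher number here means a weaker inhibitor, a lower number a stronger inhibitor.

Three compounds carry the shared core with a (cyclopropylmethyl)((oxan-4-yl)methyl)amino group or a close variant of it. Compound 1 `CCc1nn2c(-c3c(OC)cccc3OC)cccc2c1N(CC1CCOCC1)CC1CC1` gives 105 nM in this assay. Compound 2 `COCc1cc(OC)c(-c2cccc3c(N(CC4CCOCC4)CC4CC4)c(OC)nn23)c(OC)c1` gives 51 nM. Compound 3 `CCc1nn2c(-c3c(C)cc(C)cc3OC)cccc2c1N(CC1CC1)CC1CCOC1` gives 38 nM. Among these three numbers compound 2 stands second highest; its number and that of compound 3 lie within the scatter of each other, so no order between them is claimed, while compound 1 has a higher number than compound 2 and that gap lies beyond the scatter.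

Compound 4 `CCc1nn2c(-c3c(OC)cc(COC)cc3OC)cccc2c1N(CC1CCOCC1)CC1CC1` is not yet measured. It differs from compound 2 in one place: ethyl in place of methoxy on an aromatic carbon. Among the measured compounds shown here, no pair of measured compounds differs in this one place alone, so the size of such a change is not known from the numbers at hand; compound 1 and compound 3 both carry ethyl at this carbon and their numbers bracket that of compound 2.

Expectation for compound 4: a step of a 1.2-fold higher number from compound 2 to compound 4 (0.07 log units; within the scatter) from compound 2, which is estimated to stay within the scatter. Compound 4 is therefore expected to give about 60 nM in this assay, with a range from 25 nM to 150 nM.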

Compound 4, half-maximal inhibitory concentration: 50 nM
Beside the measured number, compound 4's estimate is 1.2-fold (0.08 log units) above it; low and high end bracket the measured number.
By their numbers in this assay, from the lowest: compounds 3, 4 and 2 (each within the scatter of the next); then compound 1.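

Ethyl in place of methoxy on an aromatic carbon of the five-membered aromatic ring with 2 nitrogen, next to the ring nitrogen, is now read directly in this assay as a 1.0-fold lower number from compound 2 to compound 4 (0.01 log units; within the scatter), so this position tolerates the exchange of these two groups, including the loss of one hydrogen-bond acceptor, with no difference beyond the scatter. With ethyl held the same at this carbon, methoxymethyl in place of hydrogen on an aromatic carbon gives a 2.1-fold lower number from compound 1 to compound 4 (0.32 log units; beyond the scatter), a modest step and the only one of the two that lies beyond the scatter, so among these one-place changes it is the methoxymethyl group, not the ethyl-methoxy exchange, that goes with a measurable difference. Nothing at hand gives a reason for either step.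

From the compounds shown here alone, the result covers only ethyl and methoxy at the carbon next to the ring nitrogen, so it remains open whether an amine, a carboxylic acid or a longer chain such as butyl would also stay within the scatter there. The compounds shown also leave open whether other groups in place of methoxymethyl, such as hydroxymethyl or a primary amide, would give a step of similar size.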